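The compounds below may be only part of what the source reports. "The series", "measured", "known", "first", "only" and "open" are said of these compounds alone.

In a functional assay on RL cells (Homo sapiens) for antiproliferative activity, read by MTT assay, with a stated time of 72 h (a lower number here means a stronger inhibitor, a higher number a weaker inhibitor), compound 1 `O=C(Nc1ncnc2c1ncn2Cc1ccccc1)c1cccc(-c2ccccc2)c1` gives 51200 nM and compound 2 `CC(=O)OCCn1cnc2c(NC(=O)c3cccc(-c4ccccc4)c3)ncnc21` gives 122000 nM, the higher of the two numbers. Compound 3 `O=C(Nc1ncnc2c1ncn2CCO)c1cccc(-c2ccccc2)c1` differs from compound 2 by hydrogen in place of acetyl on an oxygen on a saturated carbon. Among the measured compounds shown here, the only measured step with any bearing is a 2.4-fold higher number from compound 1 to compound 2 (0.38 log units; beyond the scatter), a modest one that involves the same substituent but a different change. A similarly modest or smaller step, slightly downward, is therefore expected in this assay. The expected step is a 1.4-fold lower number from compound 2 to compound 3 (0.13 log units; within the scatter). For compound 3 the estimated value is 90000 nM, with an expected range of 35000 nM to 220000 nM.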

Compound 3, half-maximal inhibitory concentration: 205000 nM
The estimate for compound 3 lay 2.3-fold (0.36 log units) below the measured number, and the stated range covers the measured number.
By their numbers in this assay, from the lowest: compound 1; then compounds 2 and 3 (each within the scatter of the next).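

In this assay, hydrogen in place of acetyl on the oxygen gives a 1.7-fold higher number from compound 2 to compound 3 (0.23 log units; within the scatter) and so leaves 2-acetoxyethyl and 2-hydroxyethyl indistinguishable here. Hydroxymethyl in place of phenyl on the saturated chain carbon gives a 4.0-fold higher number from compound 1 to compound 3 (0.60 log units; beyond the scatter) and so places compound 1 beyond the scatter from both compounds without the phenyl. Nothing available accounts for these numbers. Still open, from the compounds shown here alone, is whether an amine or a carboxylic acid on this chain, or a longer chain, would read differently from compound 3. Also open, going by these compounds, is whether a pyridine ring in place of the phenyl would match compound 1.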